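Basic amide tail: ring replaced by open chain

The source may hold more compounds than are shown below. What is called first, only, known or untested is meant among the compounds shown, and "the series" means these compounds.

Measured in a functional assay on NCI-H1581 cells (Homo sapiens) for antiproliferative activity, read by CCK-8 assay, with a stated time of 72 h; on this read-out higher numbers stand for weaker inhibition and lower numbers for stronger inhibition:
compound 1 `COc1cc(OC)c(Cl)c(-c2ccc3c(NC(=O)c4ccc(C5CCN(C)CC5)cc4)n[nH]c3n2)c1Cl` gives 8.2 nM
compound 2 `COc1cc(OC)c(Cl)c(-c2ccc3c(NC(=O)c4cnc(N5CCN(C)CC5)cn4)n[nH]c3n2)c1Cl` gives 60.6 nM
compound 3 `COc1cc(OC)c(Cl)c(-c2ccc3c(NC(=O)c4ccc(N5CCN(C)CC5)s4)n[nH]c3n2)c1Cl` gives 3.7 nM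

Compound 1 stands second highest of the three numbers. Compound 3 gives a lower number, beyond the scatter, and compound 2 gives the highest number, also beyond the scatter. Compound 4 `COc1cc(OC)c(Cl)c(-c2ccc3c(NC(=O)c4ccc(N(C)CCN(C)C)cc4)n[nH]c3n2)c1Cl` differs from compound 1 at the amide tail only: (2-(dimethylamino)ethyl)(methyl)amino in place of 1-methylpiperidin-4-yl on an aromatic carbon. Among the compounds with values here, no measured pair covers this change. Compounds 2 and 3 carry a nitrogen-linked basic group at the corresponding place and both stay active, so a basic tail of either kind seems tolerated. In this assay the step of a 1.3-fold higher number from compound 1 to compound 4 (0.13 log units; within the scatter) is expected to be small, close to the scatter, leaning toward a slightly higher number. Compound 4 is therefore estimated at 11 nM, with a range of 3.5 nM to 35 nM.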

Compound 4, half-maximal inhibitory concentration: 11 nM
The estimate for compound 4 equals the measured number at the digits printed, and the stated range covers the measured number.
By their numbers in this assay, from the lowest: compound 3; then compounds 1 and 4 (each within the scatter of the next); then compound 2.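

In this assay the open chain (2-(dimethylamino)ethyl)(methyl)amino in place of the ring of 1-methylpiperidin-4-yl gives a 1.3-fold higher number from compound 1 to compound 4 (0.13 log units; within the scatter). This first single-place pair shows that, on this aromatic carbon para to a large group, the ring itself is not needed to keep the number within the scatter of compound 1. Nothing available gives a reason for this outcome.

Open, going by these compounds, is how a longer chain ending in dimethylamino would read at this place. Also open, on these data alone, is whether a morpholine ring or a carboxylic acid there would stay as close to compound 1.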